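A Formylthiophene in Place of the Methylphenyl Group

The compounds below may be only part of what the source reports. "The series", "measured", "known", "first", "only" and "open" are said of these compounds alone.

Among the compounds with values here, compound 2 `Cc1ccc(Nc2nccc(-c3c(C)nc4ccccn34)n2)cc1` is the one member of this small set with a number to its name. In a functional assay on HCT-15 cells (Homo sapiens) for cytotoxicity, read by sulforhodamine B assay, with a stated time of 48 h, tested at 50 uM (on this read-out higher numbers stand for more inhibition at the one concentration tested (going by the name of the read-out) and lower numbers for less inhibition), compound 2 gives 95.2%. Its two companions carry no figure at all: compound 1 `Nc1nccc(-c2cnc3ccccc3c2)n1` is recorded in this assay as "not active" (no number reported), and compound 3 `Nc1nccc(-c2ccnc3ccccc23)n1` is recorded in this assay as "not active" (no number reported). Both lack the arylamino substituent that compound 2 carries, but without numbers behind them they cannot be set against it in size, so compound 2 stands alone at the top of what is shown, and its value leaves little room upward.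

Compound 4 `Cc1nc2ccccn2c1-c1ccnc(Nc2ccc(C=O)s2)n1` has not yet been measured. It keeps the remainder of compound 2 and alters one substituent: 5-formylthiophen-2-yl in place of 4-methylphenyl on a nitrogen on an aromatic ring. Within the data shown here, no step between measured compounds bears on this exchange, so any expectation rests on compound 2 alone. Because compound 2 gives 95.2%, the movement from it is expected to be small or downward rather than upward. The step is expected to come out as a number 15.2 percentage points lower from compound 2 to compound 4 (beyond the scatter). For compound 4 the expected value in this assay is 80%, within a range from 40% to 98%.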

Compound 4, a percentage reported as inhibition, at one concentration (the size of the read-out at that concentration, not a potency): 85.4%
Beside the measured number, compound 4's estimate is 5.4 percentage points below it; the measured number falls inside the stated range.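

In this assay, the exchange of 4-methylphenyl for 5-formylthiophen-2-yl on a nitrogen on an aromatic ring comes out as a number 9.8 percentage points lower from compound 2 to compound 4 (within the scatter). Within the data shown here, this is the first view of this position with two different groups on it, and it shows that a five-membered aromatic ring with one hetero atom and a formyl group can take the place of the six-membered ring of carbon only, with no difference that can be told from the scatter at this single concentration. No measurement shown offers an explanation of how either group acts at this position.

The compounds shown leave open whether a carboxylic acid or a hydroxymethyl group in place of the formyl group, or a thiophen-2-yl ring with no formyl group at all, would give a similar reading, and how a plain alkyl chain on the same nitrogen would compare. They also leave open how compound 2 and compound 4 would compare at lower concentrations, as only the size of inhibition at one concentration is shown.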